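A few compounds are considered here, and "the series" means these few. Any claim that something is new, unique, unknown or untested is made for them only; others in the source may bear on it.

Measured so far:
compound 1, `Cc1cc(O)c(C2=NN(c3ccc(S(N)(=O)=O)cc3)C(c3ccccc3Cl)C2)cc1Cl`, 100000 nM
compound 2, `Cc1cc(O)c(C2=NN(c3ccc(S(N)(=O)=O)cc3)C(/C=C/c3ccccc3)C2)cc1Cl`, 49700 nM

Both measurements come from a functional assay on Hs-578T cells (Homo sapiens) for antiproliferative activity, with a stated time of 48 h; a higher number here means a weaker inhibitor of growth, a lower number a stronger inhibitor of growth. Within the data shown here, of the two numbers known, compound 1 gives the highest, and its nearest neighbour is compound 2, reached by a 2.0-fold lower number from compound 1 to compound 2 (0.30 log units; within the scatter), a step that stays within the scatter. The two compounds therefore cannot be ranked against each other on these data.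

Compound 3, `COc1ccc(C2CC(c3cc(Cl)c(C)cc3O)=NN2c2ccc(S(N)(=O)=O)cc2)c(OC)c1OC`, has not yet been measured. It differs from compound 1 in a single place: 2,3,4-trimethoxyphenyl in place of 2-chlorophenyl on a saturated ring carbon. Among the measured compounds shown here, the only measured step that touches the same saturated ring carbon is the one from compound 1 to compound 2, and that step stayed within the scatter. Nothing further is known about the group that enters. For the measured compounds named here, on that basis a step within the scatter is expected in this assay, with no direction to be claimed beyond a slight leaning toward a lower number, as the one measured neighbour already shows.

The estimate for compound 3 is therefore 60000 nM, with a range of 20000 nM to 100000 nM, which would mean a step of a 1.7-fold lower number from compound 1 to compound 3 (0.22 log units; within the scatter).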

Compound 3, concentration for total growth inhibition: 7020 nM
Estimate against measurement, compound 3: 8.5-fold (0.93 log units) above, outside the stated range (below it).
By their numbers in this assay, from the lowest: compound 3; then compounds 2 and 1 (each within the scatter of the next).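

In this assay, the saturated ring carbon next to the ring nitrogen proves sensitive to the group it carries, which the earlier pair could not show: the change to 2,3,4-trimethoxyphenyl gives a 14-fold lower number from compound 1 to compound 3 (1.15 log units; beyond the scatter), and replacing 2-phenylethenyl with the same group gives a 7.1-fold lower number from compound 2 to compound 3 (0.85 log units; beyond the scatter). Compound 3 therefore stands apart from both earlier compounds, and this position can no longer be treated as indifferent to substitution, at least among these three groups. Nothing available here accounts for the size of these steps or links them to any feature of the entering group.

The compounds shown do not separate the contributions of the methoxy groups, since all of them enter together while the chlorine leaves, so it remains open whether a single methoxy group, as in 4-methoxyphenyl, would give any part of the step. Going by these compounds, it is also open whether the gain depends on an aromatic ring at this carbon at all, or whether a cyclohexyl group or a chain ending in an amine would give a similar number.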